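Swapping Methoxymethyl for Pyrimidinyl: Expected Effect on Clearance

The compounds below may be only part of what the source reports. "The series", "measured", "known", "first", "only" and "open" are said of these compounds alone.

This study asks how quickly liver enzymes remove a compound, measured in an ADME assay on microsomes from liver (Homo sapiens) for metabolic stability; a higher number here means faster removal of the compound, a lower number slower removal. Of the compounds shown here, two have been measured so far. Compound 1 `COC(=O)N1CCC(n2ccc(Cc3nc4ccccc4n3CCCCO)n2)CC1` gives 110 mL.min-1.g-1 in this assay. Compound 2 `COCc1cn(CCCCO)c(Cn2c(=O)n(C3CC3)c3ccncc32)n1` gives 9 mL.min-1.g-1 in this assay. Of the two numbers, compound 2 has the lower one, and the gap to compound 1 is larger than the usual scatter of repeated measurements, so compound 2 is removed more slowly than compound 1 by a margin that can be trusted.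

The next compound, compound 3 `O=c1n(Cc2nc(-c3ncccn3)cn2CCCCO)c2cnccc2n1C1CC1`, is made from compound 2 by a single change: pyrimidin-2-yl in place of methoxymethyl on an aromatic carbon. The two measured compounds differ in many places at once. Among the measured compounds shown here, no comparable single change has been measured, and there is no direct precedent for the size of this step. With only that to go on, the step is expected to be small in this assay, not beyond the scatter, in either direction. Compound 3 is therefore expected to give about 12 mL.min-1.g-1 in this assay, within a range of 5 mL.min-1.g-1 to 30 mL.min-1.g-1. That estimate means a step of a 1.3-fold higher number from compound 2 to compound 3 (0.12 log units; within the scatter) in this assay.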

Compound 3, intrinsic clearance in microsomes: < 8 mL.min-1.g-1
Compound 3 was reported as a limit; the forecaster's own chance of this, stated with the estimate: 10%; at least 1.5-fold (0.17 log units) between middle value and limit.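

In this assay, putting pyrimidin-2-yl in place of methoxymethyl on this aromatic carbon of the five-membered ring gives an at least 1.1-fold lower number from compound 2 to compound 3 (0.05 log units; that floor lies within the scatter), the first single change seen at this position. Compound 3 is reported as a limit of the assay, < 8 mL.min-1.g-1, and not as an exact number. The change therefore brings no sign of faster removal, even though a whole aromatic ring now stands where a small open group stood, but the true size of the step cannot be read because the result stops at a limit: the limit of < 8 mL.min-1.g-1 in this assay, at which 1 of the 3 values shown sits.

The compounds shown leave open whether this outcome belongs to pyrimidin-2-yl in particular or would also hold for another group on the same carbon, such as a plain phenyl ring or a small amine such as dimethylamino. They also leave open how much the 4-hydroxybutyl group, shared by all three compounds, contributes to the numbers in this assay, and whether a shorter chain or a carboxylic acid in its place would shift them.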